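A Shorter Chain on the Shared Core

This account rests on a few compounds, and the source may have more. Where it says the series, first, only, none or still open, it means among the compounds named here.

Compound 1 `N=C(S)CCn1nc(-c2ccccc2)ccc1=S` and compound 2 `N=C(S)CCCCCCN1N=C(c2ccccc2)CCC1=O` were both examined in a functional assay on the whole organism (stomach) for inhibition, with Rattus norvegicus as the target, at a dose of 100 mg/kg by the intraduodenal route; a higher number here means more inhibition at the dose given (going by the name of the read-out), a lower number less inhibition. Compound 1 gives 62.3% and compound 2 gives 68.3% in this assay; compound 2 holds the higher of the two numbers, but its gap to compound 1 lies within the usual scatter, so the two cannot be ranked. Compound 3 `N=C(S)CCCN1N=C(c2ccccc2)CCC1=O` is still to be measured. It differs from compound 2 by a group of 3 heavy atoms (1 carbon, 1 nitrogen, 1 sulfur; no ring) in place of a group of 6 heavy atoms (4 carbon, 1 nitrogen, 1 sulfur; no ring), on a saturated chain carbon, three bonds along the chain from an amide-type nitrogen in a ring. Within the data shown here, with no comparable step among the measured compounds, the change is expected to be small, perhaps slightly downward or none beyond the scatter: a number 8.3 percentage points lower from compound 2 to compound 3 (within the scatter). Compound 3 is therefore estimated at 60%, ranging from 40% to 80%.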

Compound 3, a percentage reported as inhibition, in the whole organism at one dose (the size of the read-out at that dose, not a potency): 50.3%
Compound 3: the middle estimate sits 9.7 percentage points above what was measured; measured number inside the range.
By their numbers in this assay, from the lowest: compound 3; then compounds 1 and 2 (each within the scatter of the next).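

In this assay, among these compounds, a group of 3 heavy atoms in place of a group of 6 heavy atoms, on a saturated chain carbon, brings a number 18 percentage points lower from compound 2 to compound 3 (beyond the scatter), so this position responds to the change in a way the earlier compounds could not show. It remains one step between one pair of compounds, and no wider pattern follows from it. Nothing given here accounts for this step.

Still open, going by these compounds, is whether a longer chain would keep the number of compound 2 or raise it. Also open, on these data alone, is how an amine or a carboxylic acid would fare at this position.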